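The compounds below may be only part of what the source reports. "The series", "measured", "known", "first", "only" and "open" are said of these compounds alone.

Measured so far:
compound 1, `CCCC(=O)c1ccc(OCCCCOc2ccc(F)c(C(=O)O)c2)c(C)c1O`: 56.9%
compound 2, `Cc1c(OCCCCOc2ccc(C(=O)O)cc2)ccc(C(=O)CC2CCCC2)c1C`: 12.2%

Within the data shown here, in an assay on HEK293 cells for positive allosteric modulation of metabotropic glutamate receptor 3 (Rattus norvegicus), read by thallium flux, with a stated time of 2.5 min (on this read-out lower numbers stand for smaller maximal responses and higher numbers for larger maximal responses), compound 1 gives 56.9% and stands highest of the two numbers known. Among the measured compounds shown here, its nearest neighbour is compound 2, which in this assay gives 12.2%, a gap that lies beyond the usual scatter; compound 2 differs from compound 1 in several places at once, so no single step between the two is available and the pair shows only that the larger chain-bearing compound reaches the smaller maximal response.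

Compound 3, `Cc1c(OCCCCOc2ccc(F)c(C(=O)O)c2)ccc(C(=O)CC(C)(C)C)c1O`, has not been measured. It keeps the core of compound 1 and differs from it in one place: tert-butyl in place of ethyl on a saturated chain carbon bound to a carbonyl carbon. For the measured compounds named here, no measured pair in the set isolates this change, so the size of the step rests on expectation alone. Going by the values given here, a step of moderate size, downward, is expected in this assay, since the only other compound with a branched chain on the carbonyl, compound 2, gives 12.2%. For compound 3 the maximal response is estimated at 45%, within 20% to 70%, which would mean a step of a number 11.9 percentage points lower from compound 1 to compound 3 (beyond the scatter).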

Compound 3, largest response reached (reported as percent of maximum), in percent of the reference or control that the assay uses: 102%
The estimate for compound 3 lay 57 percentage points below the measured number; measured number outside the range, above it.
By their numbers in this assay, from the lowest: compound 2; then compound 1; then compound 3.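

In this assay, among these compounds, the change of ethyl to tert-butyl on a saturated chain carbon bound to a carbonyl carbon gives the first step that can be read at a single place: the maximal response lies a number 45.1 percentage points higher from compound 1 to compound 3 (beyond the scatter). This shows that the chain on the carbonyl is not a silent position: with the rest of the core of compound 1 kept, the change at this one place moves the response upward, which the two earlier compounds, differing in several places at once, could not show. No measurement at hand bears on the origin of this step, so it stands as an observation on a single pair.

Going by these compounds, whether the response climbs gradually or only with tert-butyl remains open, as an isopropyl group or a longer straight chain such as butyl at this same place would be needed to tell. Also open, on these data alone, are whether an amine at this place keeps any of the response and whether the same change gives a step of similar size on the core of compound 2.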